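Aryl exchange on the shared core: compound 3 to compound 4

The source may report more compounds than this note shows. Statements on the series, on what has been measured and on what is new or still open speak of the compounds shown alone.

Measured so far in a functional assay on B16-F0 cells (Mus musculus) for inhibition, read by CCK-8 assay, with a stated time of 48 h; on this read-out higher numbers stand for weaker inhibition and lower numbers for stronger inhibition
- compound 1 `COc1cc(-c2ccnc3cc(-c4ccc(Cl)cc4)nn23)cc(OC)c1OC` gives 4090 nM
- compound 2 `COc1cc(-c2ccnc3cc(-c4ccc(C(F)(F)F)cc4)nn23)cc(OC)c1OC` gives 1770 nM
- compound 3 `COc1cc(-c2ccnc3cc(-c4ccc(C(C)=O)cc4)nn23)cc(OC)c1OC` gives 3930 nM

Compound 3 sits with compound 1 at the upper end of the three numbers (a 1.0-fold lower number from compound 1 to compound 3 (0.02 log units; within the scatter)) and above compound 2 (a 2.2-fold higher number from compound 2 to compound 3 (0.35 log units; beyond the scatter)). Compound 4 `COc1ccc(-c2cc3nccc(-c4cc(OC)c(OC)c(OC)c4)n3n2)cc1N` differs from it by 3-amino-4-methoxyphenyl in place of 4-acetylphenyl on an aromatic carbon in one exchange: 3-amino-4-methoxyphenyl in place of 4-acetylphenyl on an aromatic carbon. Among the measured compounds shown here, the remaining measured step (a 2.3-fold lower number from compound 1 to compound 2 (0.36 log units; beyond the scatter)) is modest like the one to compound 3 from compound 2, and each of these exchanges only a single group, so they bound this larger change poorly. For the measured compounds named here, no measured compound carries an amino group, and the estimate is correspondingly uncertain. A lower number is expected in this assay, by an estimated step larger than any seen so far (a 49-fold lower number from compound 3 to compound 4 (1.69 log units; beyond the scatter)). For compound 4 the expected value is 80 nM (estimated range 10 nM to 900 nM).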

Compound 4, half-maximal inhibitory concentration: 88 nM
The estimate for compound 4 lay 1.1-fold (0.04 log units) below the measured number; the measured number falls inside the stated range.
By their numbers in this assay, from the lowest: compound 4; then compound 2; then compounds 3 and 1 (each within the scatter of the next).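

At this position on the shared core, in this assay, 3-amino-4-methoxyphenyl gives a 45-fold lower number from compound 3 to compound 4 (1.65 log units; beyond the scatter), alongside a 46-fold lower number from compound 1 to compound 4 (1.67 log units; beyond the scatter) and a 20-fold lower number from compound 2 to compound 4 (1.30 log units; beyond the scatter). These steps are far larger than any among the 4-chlorophenyl, 4-(trifluoromethyl)phenyl and 4-acetylphenyl compounds, so the aryl group here can move the number much further than those exchanges suggested. Nothing available explains the drop.

On these data alone, the exchange brings in amino and methoxy together, so their separate shares remain open. An aryl group carrying only the amino or only the methoxy, or a hydroxyl in place of the amino, would address this.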